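Replacing the amide substituent on a pyrimidinyl-pyrrolidine carboxamide

A few compounds are considered here, and "the series" means these few. Any claim that something is new, unique, unknown or untested is made for them only; others in the source may bear on it.

Three compounds were tested in an assay on isolated protein for inhibition of MAP kinase-activated protein kinase 2 (Homo sapiens), read by HTRF, tested at 10 uM; on this read-out lower numbers stand for less inhibition and higher numbers for more inhibition at the one concentration tested (going by the name of the read-out). Compound 1, `CN(CCCn1ccnc1)C(=O)[C@@H]1CCCN1c1nccc(Nc2ccccc2)n1`, gives 2% in this assay. Compound 2, `Cc1cccc(Oc2ccnc(N3CCN(C(=O)c4c(C)noc4C)CC3)n2)c1`, gives 0%, and compound 3, `Cc1cccc(N(C)c2cc(Nc3cccc(C(=O)N4CCCC5CCCCC54)c3)ncn2)c1`, gives 0%. Compound 1 thus has the largest of the three numbers, but both compound 2 and compound 3 differ from it only within the usual scatter of repeated measurements, so the three cannot be told apart on these data: none of them shows inhibition at the concentration tested.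

Compound 4, `COC[C@@H]1CCCN1C(=O)[C@@H]1CCCN1c1nccc(Nc2ccccc2)n1`, has not yet been measured. It differs from compound 1 in one place: 2-(methoxymethyl)pyrrolidin-1-yl in place of (3-(1H-imidazol-1-yl)propyl)(methyl)amino on a carbonyl carbon. Going by the values given here, no step between measured compounds exists that would show how this assay answers to such a change. Since compound 1 shows no inhibition at 2% and the two unrelated compounds sit at the same level, compound 4 is expected to remain at that level as well. The expected step of a number 1 percentage points higher from compound 1 to compound 4 (within the scatter) is therefore none beyond the scatter. Compound 4 is estimated to give 3%, with a range from -7% to 14%.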

Compound 4, a percentage reported as inhibition, at one concentration (the size of the read-out at that concentration, not a potency): 1%
For compound 4 the middle estimate is 2 percentage points above the measured one; the range from low to high includes it.
By their numbers in this assay, from the lowest: compounds 2, 3, 4 and 1 (each within the scatter of the next).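

In this assay, going by these compounds alone, the exchange of (3-(1H-imidazol-1-yl)propyl)(methyl)amino for 2-(methoxymethyl)pyrrolidin-1-yl on the carbonyl carbon gives a number 1 percentage points lower from compound 1 to compound 4 (within the scatter), the first step that can be read at this position. The five-membered aromatic ring with 2 hetero atoms can thus give way to a five-membered non-aromatic ring with 1 hetero atom and a defined stereocentre without a difference that this read-out can tell, and neither substituent brings inhibition at the concentration tested. Nothing available explains why the two substituents read alike. On these data alone, whether a carboxylic acid or a primary amine at the end of a longer chain on this carbonyl carbon would give a number beyond the scatter stays open. Also open, as far as these compounds go, is whether the shared core can show inhibition in this assay with any substituent there.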